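Phenol variation on the acylhydrazone aryl of a series

A few compounds are considered here, and "the series" means these few. Any claim that something is new, unique, unknown or untested is made for them only; others in the source may bear on it.

Compound 1 `CN(C)CCn1cnnc1-c1cc(Oc2ccc(NC(=O)N/N=C/c3ccc(F)cc3)cc2F)ccn1` gives 1980 nM in a functional assay on NCI-H460 cells (Homo sapiens) for cytotoxicity, read by MTT assay, with a stated time of 72 h (on this read-out higher numbers stand for weaker inhibition and lower numbers for stronger inhibition), and compound 2 `COc1ccc(/C=N/NC(=O)Nc2ccc(Oc3ccnc(-c4nncn4CCN(C)C)c3)c(F)c2)cc1O` gives 620 nM. Among the measured compounds shown here, the only step on record, a 3.2-fold lower number from compound 1 to compound 2 (0.50 log units; beyond the scatter), is the sole guide here, and compound 2 holds the lowest number of the two. Compound 3 `Cc1cc(/C=N/NC(=O)Nc2ccc(Oc3ccnc(-c4nncn4CCN(C)C)c3)c(F)c2)cc(C)c1O` carries 4-hydroxy-3,5-dimethylphenyl in place of 3-hydroxy-4-methoxyphenyl on a carbon with a double bond to nitrogen. Since the hydroxyl group is kept while the methoxy is exchanged for two methyl groups, the step is expected to be small, within or near the scatter, in either direction, a 1.2-fold higher number from compound 2 to compound 3 (0.08 log units; within the scatter). Compound 3 is therefore estimated at 750 nM, between 250 nM and 2200 nM.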

Compound 3, half-maximal inhibitory concentration: 2010 nM
The estimate for compound 3 lay 2.7-fold (0.43 log units) below the measured number, within the range that was stated.
By their numbers in this assay, from the lowest: compound 2; then compounds 1 and 3 (each within the scatter of the next).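

Keeping a hydroxyl group on the aryl ring did not preserve the result of compound 2: a 3.2-fold higher number from compound 2 to compound 3 (0.51 log units; beyond the scatter), so 4-hydroxy-3,5-dimethylphenyl and 3-hydroxy-4-methoxyphenyl are not interchangeable on this carbon with a double bond to nitrogen. The phenol of compound 3 also stands level with the 4-fluorophenyl group, a 1.0-fold higher number from compound 1 to compound 3 (0.01 log units; within the scatter), so a hydroxyl group alone does not separate these aryl groups. Nothing available here explains this difference.

From the compounds shown here alone, it remains open whether the methoxy group or the hydroxyl placement accounts for the lower number of compound 2. A 3-hydroxyphenyl group, a 4-methoxyphenyl group or an aminophenyl group at this carbon also remains to be compared.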